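Anilide boronate series: aryl substitution on the amide ring

The compounds below may be only part of what the source reports. "The series", "measured", "known", "first", "only" and "open" are said of these compounds alone.

Measured so far in a functional assay on HCT-116 cells (Homo sapiens) for antiproliferative activity, read by MTT assay, with a stated time of 72 h; a higher number here means a weaker inhibitor, a lower number a stronger inhibitor:
compound 1 `O=C(CCc1cccc2c1B(O)OC2)Nc1ccccc1` — 350 nM
compound 2 `COc1ccc(NC(=O)CCc2cccc3c2B(O)OC3)cc1` — 1700 nM
compound 3 `C#Cc1ccccc1NC(=O)CCc1cccc2c1B(O)OC2` — 1400 nM

Compound 1 holds the lowest of the three numbers in this assay. The two substituted anilides sit higher: a 4.9-fold higher number from compound 1 to compound 2 (0.69 log units; beyond the scatter) and a 4.0-fold higher number from compound 1 to compound 3 (0.60 log units; beyond the scatter), both beyond the scatter and both in the weakening direction.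

Compound 4 `COc1ccc(-c2cccc(NC(=O)CCc3cccc4c3B(O)OC4)c2)cc1` differs from compound 1 at one place: 4-methoxyphenyl in place of hydrogen on an aromatic carbon. The steps to compound 2 and to compound 3 are the relevant comparisons, since each adds a group on the same ring of the core of compound 1. On that basis a weakening step of similar size is expected, a 4.3-fold higher number from compound 1 to compound 4 (0.63 log units; beyond the scatter).

Compound 4 is therefore estimated at 1500 nM in this assay, expected to fall between 500 nM and 5000 nM.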

Compound 4, half-maximal inhibitory concentration: 160 nM
Compound 4: the middle estimate sits 9.4-fold (0.97 log units) above what was measured, outside the stated range (below it).
By their numbers in this assay, from the lowest: compound 4; then compound 1; then compounds 3 and 2 (each within the scatter of the next).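

In this assay the 4-methoxyphenyl group, on an aromatic carbon meta to a large group, runs opposite to the methoxy and ethynyl steps: a 2.2-fold lower number from compound 1 to compound 4 (0.34 log units; beyond the scatter) and so the first lowering of the number from compound 1 among these compounds. Adding to this ring of the core therefore does not always weaken, and a group of this size is compatible with activity here. Nothing available accounts for the reversal.

Open, going by these compounds, is whether plain phenyl at this place would give the same lowering. Also open, on these data alone, is whether an amine or a carboxylic acid in place of the methoxy on the added ring would preserve it.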